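Replacing Chloro with Methylsulfanyl: What to Expect for Compound 3

The source may hold more compounds than are shown below. What is called first, only, known or untested is meant among the compounds shown, and "the series" means these compounds.

Going by the values given here, compound 1 `OCC#CCSc1cnc2ccccc2c1Cl` gives 6.2 ug/mL in a functional assay on SW707 cells (Homo sapiens) for cytotoxicity, read by sulforhodamine B assay, with a stated time of 72 h (on this read-out higher numbers stand for weaker inhibition and lower numbers for stronger inhibition), the higher of the two numbers measured so far, though its gap to the other is within the scatter. That other is compound 2 `C[Se]c1c(SCC#CCO)cnc2ccccc12`, which gives 3.5 ug/mL, a step of a 1.8-fold lower number from compound 1 to compound 2 (0.25 log units; within the scatter). Compound 3 `CSc1c(SCC#CCO)cnc2ccccc12` has not yet been measured. It differs from compound 1 by methylsulfanyl in place of chloro on an aromatic carbon, on an aromatic carbon of a six-membered aromatic ring with one nitrogen, part of a fused system of two rings, opposite the ring nitrogen. Among the compounds with values here, the only step that bears on this change is a 1.8-fold lower number from compound 1 to compound 2 (0.25 log units; within the scatter), a closely related replacement at the same carbon, which stayed within the scatter. No step beyond the scatter is therefore expected for the new compound. Compound 3 is expected to show a 1.5-fold lower number from compound 1 to compound 3 (0.17 log units; within the scatter), an estimate of 4.2 ug/mL with a range from 2 ug/mL to 9 ug/mL.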

Compound 3, concentration for 50% inhibition: 69.3 ug/mL
Estimate against measurement, compound 3: 17-fold (1.22 log units) below; measured number outside the range, above it.
By their numbers in this assay, from the lowest: compounds 2 and 1 (each within the scatter of the next); then compound 3.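

In this assay, the carbon opposite the ring nitrogen proved sensitive to the group it carries: methylsulfanyl in place of chloro brought an 11-fold higher number from compound 1 to compound 3 (1.05 log units; beyond the scatter) where the earlier replacement at this carbon had stayed within the scatter. Exchanging selenium for sulfur, with the count of heavy atoms in the group unchanged, gave a 20-fold higher number from compound 2 to compound 3 (1.30 log units; beyond the scatter) and so showed that this count alone does not set the number at this position. Nothing measured here explains why the sulfur and selenium groups part so widely.

As far as these compounds go, whether an amine, a methoxy group or a longer alkylsulfanyl chain at this carbon would stay close to compound 1 or rise like compound 3 remains open. Also open, from the compounds shown here alone, is whether the gap between sulfur and selenium persists when the shared core carries a different side chain.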